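From compound 2 to compound 4: an ethoxycarbonyl exchange

A few compounds are considered here, and "the series" means these few. Any claim that something is new, unique, unknown or untested is made for them only; others in the source may bear on it.

In a functional assay on the whole organism (trachea) for inhibition, with Cavia porcellus as the target (on this read-out higher numbers stand for an effect only at larger amounts of compound and lower numbers for an effect already at smaller amounts), compound 2 (`COc1ccccc1OCC1N(C(=O)C[S+](C)[O-])CC[S+]1[O-]`) gives 25 mg/kg. Compound 3 (`O=C(Cn1ccnc1)N1CCSC1COc1ccccc1O`) gives 27 mg/kg, and compound 1 (`O=C(O)[C@@H]1CSC(CCc2ccccc2O)N1`) gives 45 mg/kg. Both lie within the scatter of compound 2, so the three numbers cannot be ranked.

Compound 4 (`CCOC(=O)CC(=O)N1CC[S+]([O-])C1COc1ccccc1OC`) has not yet been measured in this assay. Compared with compound 2, it carries a group of 5 heavy atoms (3 carbon, 2 oxygen; no ring) in place of a group of 3 heavy atoms (1 carbon, 1 oxygen, 1 sulfur; no ring), on a saturated chain carbon bound to a carbonyl carbon. The entering group is ethoxycarbonyl.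

Among the measured compounds shown here, no measured pair differs in one place, so the effect of this exchange has no direct precedent. For the measured compounds named here, the only guide is the narrow spread among structurally different compounds: compound 3 at 27 mg/kg and compound 1 at 45 mg/kg both remain within the scatter of compound 2. No step beyond the scatter is therefore expected in this assay, in either direction, though three values give weak support. The estimated 1.2-fold higher number from compound 2 to compound 4 (0.08 log units; within the scatter) stays within the scatter. For compound 4 the expected value is 30 mg/kg, with an estimated range of 13 mg/kg to 70 mg/kg.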

Compound 4, dose for half-maximal effect: 28 mg/kg
Beside the measured number, compound 4's estimate is 1.1-fold (0.03 log units) above it, and the stated range covers the measured number.
By their numbers in this assay, from the lowest: compounds 2, 3, 4 and 1 (each within the scatter of the next).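

In this assay, among the compounds shown here, the exchange of the group of 3 heavy atoms for ethoxycarbonyl, on a saturated chain carbon bound to a carbonyl carbon, gives the only step that can be read for a single change: a 1.1-fold higher number from compound 2 to compound 4 (0.05 log units; within the scatter). Within this pair, the read-out therefore does not depend on keeping the sulfur-bearing group at this place, and the group of 5 heavy atoms is tolerated. Nothing available explains this tolerance.

As far as these compounds go, it remains open whether a free carboxylic acid, an amine or a longer chain at the same place would also stay within the scatter of compound 2. This single pair also leaves open whether ethoxycarbonyl would behave the same way on the core of compound 3.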